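A few compounds are considered here, and "the series" means these few. Any claim that something is new, unique, unknown or untested is made for them only; others in the source may bear on it.

Compound 1 `CCc1cccc2c(OC)c(-c3occ(C)c3C(=O)OC)ccc12` gives 1.7 ug/mL in a functional assay on KB cells (Homo sapiens) for cytotoxicity, read by MTT assay, with a stated time of 72 h; a higher number here means that more compound is needed for the effect, a lower number that less compound is needed. Compound 2 `CCc1cccc2c(OC)c(-c3occ(C)c3CO)ccc12` gives 7.1 ug/mL. Compound 3 `CCc1cccc2c(OC)c(-c3occ(C)c3COC)ccc12` returns only a limit of the assay, > 10 ug/mL.

Compound 3 therefore stands at the edge of what the assay reports: its value is the limit of > 10 ug/mL in this assay, at which 1 of the 3 values shown sits, not a number, so its place relative to the others is known only in one direction. The step of an at least 5.8-fold higher number from compound 1 to compound 3 (0.76 log units; beyond the scatter) and the step of an at least 1.4-fold higher number from compound 2 to compound 3 (0.14 log units; that floor lies within the scatter) both lead to it, the first beyond the scatter, the second with a floor that lies within it.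

Compound 4 `CCOCc1c(C)coc1-c1ccc2c(CC)cccc2c1OC` differs from compound 3 by methyl in place of hydrogen on a saturated chain carbon bound to an oxygen on a saturated carbon. For the measured compounds named here, no measured step changes this chain on the oxygen on a saturated carbon; the nearest one, an at least 1.4-fold higher number from compound 2 to compound 3 (0.14 log units; that floor lies within the scatter), which puts a methyl onto that oxygen, has a floor within the scatter. So no step beyond the scatter is expected in this assay, and compound 3 already sits at the limit. Compound 4 is expected at about 15 ug/mL, within 7 ug/mL to 40 ug/mL, a step that the limit leaves unreadable from compound 3 to compound 4, most likely again reported only as a limit.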

Compound 4, concentration for half-maximal effect: > 10 ug/mL
Compound 4 ended at the assay's limit (the forecaster's own chance of this, stated with the estimate: 70%); the middle value lies beyond the limit too.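

Going from methoxymethyl to ethoxymethyl does not bring the compound back within the readable range of this assay, and the step between compound 3 and compound 4 cannot be read because both rest on the same limit: the limit of > 10 ug/mL in this assay, at which 2 of the 4 values shown sit. Measured against methoxycarbonyl, the ethoxymethyl group shows what the methoxymethyl group showed, with an at least 5.8-fold higher number from compound 1 to compound 4 (0.76 log units; beyond the scatter). Measured against hydroxymethyl, the result is an at least 1.4-fold higher number from compound 2 to compound 4 (0.14 log units; that floor lies within the scatter), so this comparison does not separate the two compounds.

Going by these compounds, how far compound 3 and compound 4 lie past the limit remains open, as does whether a longer chain on that oxygen would change the reading. Also open, on these data alone, is how an amine or a carboxylic acid in place of methoxycarbonyl would compare with compound 1.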